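Shrinking the Sulfonyl Substituent: Cyclopropyl to Methyl

A few compounds are considered here, and "the series" means these few. Any claim that something is new, unique, unknown or untested is made for them only; others in the source may bear on it.

Compound 1: `CC(C)NCCS(=O)(=O)NC(=O)c1ccc(Nc2nc(NC3(c4ccc(Cl)cc4)CC3)nc(OCC(F)(F)F)n2)cc1`; in an ADME assay on microsomes from liver (Rattus norvegicus) for metabolic stability, with a stated time of 10 min (a lower number here means that less of the compound is left, a higher number that more of the compound is left), compound 1 gives 100%
Compound 2: `O=C(NS(=O)(=O)C1CC1)c1ccc(Nc2nc(NC3(c4ccc(Cl)cc4)CC3)nc(OCC(F)(F)F)n2)cc1`; in this assay compound 2 gives 85%

For the measured compounds named here, compound 2 stands lowest of the two numbers measured in this assay; its only neighbour, compound 1, lies above it. Going by the values given here, the single measured step, a number 15 percentage points lower from compound 1 to compound 2 (beyond the scatter), is a modest drop beyond the scatter. In that step cyclopropyl stands in place of 2-(isopropylamino)ethyl on the sulfonyl sulfur. That step is the only one bearing on the next compound, since both concern the same sulfonyl sulfur.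

Compound 3 is `CS(=O)(=O)NC(=O)c1ccc(Nc2nc(NC3(c4ccc(Cl)cc4)CC3)nc(OCC(F)(F)F)n2)cc1`. It differs from compound 2 in one place: methyl in place of cyclopropyl on a sulfonyl sulfur, the cyclopropyl leaving and methyl entering on the sulfonyl sulfur whose other neighbour is an amide-type nitrogen. Among the compounds with values here, the change is smaller than the one from compound 1 to compound 2, and it goes in the direction of a smaller group again. For compound 3 a step of a number 5 percentage points lower from compound 2 to compound 3 (within the scatter) is expected, that is, no move beyond the scatter. The estimate for compound 3 in this assay is therefore 80%, expected to fall between 60% and 100%.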

Compound 3, percent of the compound remaining: 85%
Beside the measured number, compound 3's estimate is 5 percentage points below it; measured number inside the range.
By their numbers in this assay, from the lowest: compounds 2 and 3 (each within the scatter of the next); then compound 1.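

In this assay, putting methyl in place of cyclopropyl on the sulfonyl sulfur gives no change at the digits printed from compound 2 to compound 3 (within the scatter) and so does not separate the two groups, even though the three-membered ring is lost. The earlier step could not separate the loss of the 2-(isopropylamino)ethyl group from the arrival of a ring, but this result can: with no ring on the sulfonyl sulfur, the comparison with compound 1 still gives a number 15 percentage points lower from compound 1 to compound 3 (beyond the scatter) and matches the earlier step in size. The lower number therefore goes with the absence of 2-(isopropylamino)ethyl from this position and not with the cyclopropyl ring in particular, although only these compounds support that reading.

Still open, on these data alone, is which part of 2-(isopropylamino)ethyl goes with the higher number, the amine or the chain, and a plain propyl chain, a primary amine on the same ethyl chain or a carboxylic acid at this position would each bear on that question. Nothing in the data given explains the differences between these numbers.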